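Swapping the aryl substituent on the thioether of compound 3

The compounds below may be only part of what the source reports. "The series", "measured", "known", "first", "only" and "open" are said of these compounds alone.

Compound 3 `OC[C@H]1O[C@@H](n2cnc3c(CSc4cccc(Cl)c4)ncnc32)[C@H](O)[C@@H]1O` gives the lowest of the three numbers measured in an assay on isolated protein for binding affinity to Equilibrative nucleoside transporter 1 (Homo sapiens) (a higher number here means a weaker inhibitor, a lower number a stronger inhibitor), namely 282 nM. Compound 1 `OC[C@H]1O[C@@H](n2cnc3c(NCc4ccco4)ncnc32)[C@H](O)[C@@H]1O` gives 36300 nM, and compound 2 `OC[C@H]1O[C@@H](n2cnc3c(Sc4ccccc4)ncnc32)[C@H](O)[C@@H]1O` gives 91200 nM. The steps into compound 3 are both large: a 130-fold lower number from compound 1 to compound 3 (2.11 log units; beyond the scatter) and a 320-fold lower number from compound 2 to compound 3 (2.51 log units; beyond the scatter), while a 2.5-fold higher number from compound 1 to compound 2 (0.40 log units; beyond the scatter) is modest.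

Compound 4 `COc1ccc(SCc2ncnc3c2ncn3[C@@H]2O[C@H](CO)[C@@H](O)[C@H]2O)cc1` differs from compound 3 in one place: 4-methoxyphenyl in place of 3-chlorophenyl on a sulfur. None of the three measured steps bears directly on this change; each of them replaces the whole group on the aromatic carbon of the shared core rather than swapping one substituent on the six-membered aromatic ring of carbon only for another. Among the measured compounds shown here, the measured data therefore show only that compound 3, carrying a (3-chlorophenyl)sulfanyl group, stands far below compounds 1 and 2, and give no guide to how a (4-methoxyphenyl)sulfanyl group would compare.

Compound 4 is therefore expected to stay close to compound 3, with a step of a 1.6-fold higher number from compound 3 to compound 4 (0.20 log units; within the scatter) that may well fall within the scatter. The estimate for compound 4 in this assay is 450 nM, with a range from 120 nM to 1800 nM.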

Compound 4, half-maximal inhibitory concentration: 617 nM
Beside the measured number, compound 4's estimate is 1.4-fold (0.14 log units) below it, within the range that was stated.
By their numbers in this assay, from the lowest: compound 3; then compound 4; then compound 1; then compound 2.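

Among the compounds shown here, compound 4 gives the first reading of a change made on the sulfur itself, with the rest of compound 3 left intact: a 2.2-fold higher number from compound 3 to compound 4 (0.34 log units; beyond the scatter) is a modest step beyond the scatter, far smaller than the large steps that led into compound 3 from compound 1 and compound 2. In this assay, compound 4 gives 617 nM, while compound 1 gives 36300 nM and compound 2 gives 91200 nM, so among these compounds the low numbers are not confined to the 3-chlorophenyl group. Nothing available explains why the 4-methoxyphenyl group gives the higher number in this pair.

This single step changes both the substituent and its place on the aromatic ring, so it cannot show how much of the difference belongs to each. A 4-chlorophenyl or 3-methoxyphenyl group on the same sulfur would separate the two, while the compounds shown also leave open how an unsubstituted phenyl group or a 3-aminophenyl group would compare in this series.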